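A methoxy-to-methyl swap in a series showing no inhibition

This account rests on a few compounds, and the source may have more. Where it says the series, first, only, none or still open, it means among the compounds named here.

Measured compounds:
Compound 1, `N#Cc1c(-c2ccc(F)c(Br)c2)no[n+]1[O-]`, in an assay on isolated protein for inhibition of glutathione reductase, mitochondrial (Homo sapiens), using NADPH, with a stated time of 15 min (a higher number here means a weaker inhibitor, a lower number a stronger inhibitor), gives > 50000 nM, a limit of the assay.
Compound 2, `COc1ccc(-c2no[n+]([O-])c2C#N)cc1`, gives in this assay > 50000 nM, again a limit and not a number.

Compound 2 therefore stands at the limit of the assay, and the same is true of every value shown, as the limit of > 50000 nM in this assay, at which 2 of the 2 values shown sit, records. For the measured compounds named here, no step between two measured compounds can be drawn, so nothing is known about how any change of structure moves the read-out here.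

Compound 3 is `Cc1ccc(-c2no[n+]([O-])c2C#N)cc1`. Relative to compound 2 it carries methyl in place of methoxy on an aromatic carbon; that is, methyl in place of methoxy on an aromatic carbon. With both measured values sitting at a limit, no step beyond the scatter can be expected in this assay in either direction. The expected step that the limit leaves unreadable from compound 2 to compound 3 is essentially none. Compound 3 is therefore estimated at 100000 nM, with a range from 30000 nM to 500000 nM, most likely reported again only as a limit.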

Compound 3, half-maximal inhibitory concentration: > 50000 nM
Compound 3: no number, only a limit; the forecaster's own chance of this, stated with the estimate: 85%; the middle value is on the limit's open side.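

No step from compound 2 to compound 3 can be read in this assay, because both values are limits and not numbers: the limit of > 50000 nM in this assay, at which 3 of the 3 values shown sit.

The compounds shown leave open whether methyl and methoxy differ at all here, and which change to the shared core, if any, would give a measurable value in this assay.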